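The source may hold more compounds than are shown below. What is called first, only, known or untested is meant among the compounds shown, and "the series" means these compounds.

Measured in an in vivo ADME assay on the whole organism for pharmacokinetics, with Rattus norvegicus as the target, read by LC-MS, at a dose of 3 mg/kg by the oral route; on this read-out higher numbers stand for higher exposure at the dose given and lower numbers for lower exposure

Compound 1 `Cc1cc(-c2n[nH]c(-c3ccnc(Cl)c3)n2)ccn1` gives 15000 nM
Compound 2 `COc1cc(-c2nc(-c3ccnc(C#N)c3)n[nH]2)ccn1` gives 719 nM
Compound 3 `CC(C)COc1cc(-c2nc(-c3ccnc(C#N)c3)n[nH]2)ccn1` gives "not determined" (no result reported)

Compound 3 has no place on this scale: in this assay the result for compound 3 reads "not determined" (no result reported) and offers no number to start from. Compound 4 `N#Cc1cc(-c2n[nH]c(-c3ccnc(Cl)c3)n2)ccn1` has not been measured yet. The structural change is chloro in place of isobutoxy on an aromatic carbon and nothing else differs.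

With no starting value, the size of this step cannot be expected in numbers, and only the two measured compounds can guide an expectation. Compound 1 also carries chloro and gives 15000 nM in this assay while the nitrile-bearing compound 2 gives 719 nM there. Compound 4 holds both of these groups, so a value somewhere between those two is expected, though two compounds are thin support and the range must stay wide. Compound 4 is estimated to give 3000 nM (500 nM to 15000 nM).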

Compound 4, maximal plasma concentration: 18900 nM
Beside the measured number, compound 4's estimate is 6.3-fold (0.80 log units) below it, outside the stated range (above it).
By their numbers in this assay, from the lowest: compound 2; then compounds 1 and 4 (each within the scatter of the next).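

Chloro in place of methoxy on an aromatic carbon, next to the ring nitrogen, gives a 26-fold higher number from compound 2 to compound 4 (1.42 log units; beyond the scatter) in this assay and so shows that this one change is enough for a large step, which compound 1 and compound 2 could not show, as they differ in two places. Cyano in place of methyl on an aromatic carbon gives a 1.3-fold higher number from compound 1 to compound 4 (0.10 log units; within the scatter) in this assay and so stays within the scatter, which means that among these compounds the large step goes with the change at the chloro position. Nothing shown gives a reason for either step.

Steps from compound 3 cannot be read, so the effect of isobutoxy at this position stays unknown. On these data alone, whether an amine or a longer chain there would read like chloro or like methoxy also remains open.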